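From sec-butyl to pentan-3-yl on a nitrogen

The source may report more compounds than this note shows. Statements on the series, on what has been measured and on what is new or still open speak of the compounds shown alone.

Values in an ADME assay on the whole organism for inhibition, with Oryza sativa as the target, with a stated time of 4 days (a lower number here means a stronger inhibitor, a higher number a weaker inhibitor), for the three measured compounds:
compound 1 `CCN(c1nc(Cl)nc(N[C@H](C)c2ccccc2)n1)C(C)C` gives 3550 nM
compound 2 `CC[C@H](C)Nc1nc(Cl)nc(N[C@@H](C)c2ccccc2)n1` gives 6920 nM
compound 3 `CC[C@@H](C)Nc1nc(Cl)nc(N[C@H](C)c2ccccc2)n1` gives 8320 nM

Compound 2 holds the middle of the three numbers at 6920 nM and lies within the scatter of both compound 1 and compound 3. Compound 4 `CCC(CC)Nc1nc(Cl)nc(N[C@@H](C)c2ccccc2)n1` has not yet been measured. It carries pentan-3-yl in place of sec-butyl on a nitrogen on an aromatic ring. Going by the values given here, two measured steps bear on this change. The first, a 1.2-fold higher number from compound 2 to compound 3 (0.08 log units; within the scatter), comes with the fact that compounds 2 and 3 differ only in the configuration as drawn and stays within the scatter. Among the compounds with values here, the second, a 2.3-fold higher number from compound 1 to compound 3 (0.37 log units; beyond the scatter), is the only measured change of this amino group, and it is modest. On steps of this size, only a small change is expected in this assay and none beyond the scatter. The expected change is a 1.1-fold lower number from compound 2 to compound 4 (0.03 log units; within the scatter) in this estimate. For compound 4 the estimated value is 6500 nM with an expected range from 2800 nM to 15000 nM in the measurement to come.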

Compound 4, half-maximal inhibitory concentration: 35500 nM
Compound 4: the middle estimate sits 5.5-fold (0.74 log units) below what was measured; measured number above the stated range.
By their numbers in this assay, from the lowest: compounds 1, 2 and 3 (each within the scatter of the next, the first and the last beyond it); then compound 4.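

In this assay, going by these compounds alone, the group on this nitrogen turns out to matter more than the earlier compounds suggested: a 5.1-fold higher number from compound 2 to compound 4 (0.71 log units; beyond the scatter) comes with pentan-3-yl in place of sec-butyl, and compound 4 has the highest number of the four compounds. This step also removes the defined stereocentre of sec-butyl, yet its size stands apart from a 1.2-fold higher number from compound 2 to compound 3 (0.08 log units; within the scatter), which stays within the scatter and rests on: the fact that compounds 2 and 3 differ only in the configuration as drawn

The compounds shown do not separate the effect of the longer pentan-3-yl branches from that of losing the stereocentre at this carbon. Going by these compounds, it also remains open how a cyclopentyl group, a tert-butyl group or an unbranched pentyl chain on this nitrogen would read in this assay.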